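Ester to acid on the thioether series, cytotoxicity

A few compounds are considered here, and "the series" means these few. Any claim that something is new, unique, unknown or untested is made for them only; others in the source may bear on it.

Measured compounds: compound 1 `COc1nc2ccc(CSc3ccc(Cl)c(Cl)c3)cc2nc1OC`, 75000 nM; compound 2 `CCOC(=O)c1ccc(SCc2ccc3nc(OC)c(OC)nc3c2)cc1`, > 100000 nM.

In an ADME assay on Vero 76 cells (Chlorocebus sabaeus) for cytotoxicity, read by MTT assay, with a stated time of 96 h (on this read-out lower numbers stand for higher toxicity in this test and higher numbers for lower toxicity in this test), compound 1 gives 75000 nM. Compound 2 gives only > 100000 nM, a limit of the assay and not a number; this is the limit of > 100000 nM in this assay, at which 1 of the 2 values shown sits. Within the data shown here, compound 1 and compound 2 differ in more than one place, so no single step between measured compounds is available. Compound 3 `COc1nc2ccc(CSc3ccc(C(=O)O)cc3)cc2nc1OC` is not yet measured; it differs from compound 2 by hydrogen in place of ethyl on an oxygen next to a carbonyl group. The step that the limit leaves unreadable from compound 2 to compound 3 is expected to be none beyond the scatter. Compound 3 is estimated at 150000 nM, within 60000 nM to 400000 nM, most likely again reported as a limit.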

Compound 3, half-maximal cytotoxic concentration: 65000 nM
Compound 3: middle estimate off by 2.3-fold (0.36 log units), on the high side, within the range that was stated.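

In this assay, hydrogen in place of ethyl on an oxygen next to a carbonyl group gives an at least 1.5-fold lower number from compound 2 to compound 3 (0.18 log units; that floor lies within the scatter). The value for compound 2 is a limit of the assay and not a number: the limit of > 100000 nM in this assay, at which 1 of the 3 values shown sits.

The carboxy end of this position therefore has a readable value, with compound 3 at 65000 nM. The change from ethoxycarbonyl to carboxy, however, has only a floor, and that floor shows no step beyond the scatter. As far as these compounds go, the full size of the step stays open, as does the reading for a primary amide or a methyl ester at this position.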